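A few compounds are considered here, and "the series" means these few. Any claim that something is new, unique, unknown or untested is made for them only; others in the source may bear on it.

Of the compounds shown here, three have been measured in an assay on isolated protein for inhibition of coagulation factor X (Oryctolagus cuniculus), tested at 1 uM; a higher number here means more inhibition at the concentration tested (going by the name of the read-out), a lower number less inhibition. Compound 1 `O=C1[C@@H](NS(=O)(=O)c2cc3ncccc3s2)CCN1Cc1cc2c[nH]ccc-2n1` gives 61% and stands at the top of the three numbers shown. Compound 3 `Cc1c(S(=O)(=O)N[C@H]2CCN(Cc3cc4cc[nH]cc-4n3)C2=O)sc2ccc(Cl)cc12` gives 52%, a number within the usual scatter of that of compound 1, so the two cannot be ordered. Compound 2 `O=C1[C@@H](NS(=O)(=O)c2nc3cc(Cl)ccc3[nH]2)CCN1CCNc1ccncc1` gives 29%, a number lying beyond the scatter below that of compound 1.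

Compound 4 `O=C1[C@@H](NS(=O)(=O)c2cc3ccnc(Cl)c3s2)CCN1Cc1cc2c[nH]ccc-2n1` has not yet been measured in this assay. It differs from compound 1 in one place: a group of 10 heavy atoms (7 carbon, 1 nitrogen, 1 sulfur, 1 chlorine; one five-membered aromatic ring with 1 hetero atom, one six-membered aromatic ring with 1 hetero atom) in place of a group of 9 heavy atoms (7 carbon, 1 nitrogen, 1 sulfur; one five-membered aromatic ring with 1 hetero atom, one six-membered aromatic ring with 1 hetero atom), on a sulfonyl sulfur. Going by the values given here, no pair of measured compounds isolates this change, so its size is not known from any measured step. Because compound 3, whose structure also carries a chlorine, gives 52%, a number within the scatter of compound 1, there is no ground to expect a large move. The expected step of a number 3 percentage points lower from compound 1 to compound 4 (within the scatter) lies within the usual scatter, in no clear direction. Compound 4 is therefore estimated to give 58% in this assay, with a range from 35% to 78%.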

Compound 4, a percentage reported as inhibition, at one concentration (the size of the read-out at that concentration, not a potency): 25%
Estimate against measurement, compound 4: 33 percentage points above; the whole stated range lies above it.
By their numbers in this assay, from the lowest: compounds 4 and 2 (each within the scatter of the next); then compounds 3 and 1 (each within the scatter of the next).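

The group on the sulfonyl sulfur proves to be a sensitive place in this assay: with the rest of the molecule unchanged, replacing the group of 9 heavy atoms with the chlorine-bearing group of 10 heavy atoms gives a number 36 percentage points lower from compound 1 to compound 4 (beyond the scatter). The two groups have the same counts of rings, hetero atoms, hydrogen-bond donors and acceptors, so a large loss can arise here without any change in those counts, although the structures show that the chlorine is not the only difference, as the ring atoms are also arranged differently. Nothing available explains this drop.

The compounds shown leave open whether the chlorine or the rearranged ring atoms account for the step. They also leave open whether a fluorine, a methyl or a methoxy group in place of the chlorine would give a similar number.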